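Removing a Methylsulfanyl Group from a Benzylamine Side Chain

A few compounds are considered here, and "the series" means these few. Any claim that something is new, unique, unknown or untested is made for them only; others in the source may bear on it.

Compound 1 `CSc1ccc(CNc2nc(SC)nc3ncccc23)cc1` holds the lowest number of the two measured compounds: in a functional assay on MCF7 cells (Homo sapiens) for cytotoxicity, read by MTT assay, with a stated time of 72 h (a higher number here means a weaker inhibitor of growth, a lower number a stronger inhibitor of growth), compound 1 gives 4370 nM. Compound 2 `CCCCC[Se]c1nc(NCc2ccccc2)c2ccccc2n1` gives 47100 nM in this assay, a gap beyond the usual scatter. Compound 3 `CSc1nc(NCc2ccccc2)c2cccnc2n1` differs from compound 1 in one place, (hydrogen in place of methylsulfanyl on an aromatic carbon), hydrogen in place of methylsulfanyl on an aromatic carbon. Going by the values given here, no measured pair shows what this change does, so in this assay only a small step is expected, most likely toward a slightly higher number or none beyond the scatter. Compound 3 is therefore expected to give 6000 nM, within a range from 2000 nM to 20000 nM, an estimated step of a 1.4-fold higher number from compound 1 to compound 3 (0.14 log units; within the scatter).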

Compound 3, concentration for total growth inhibition: > 100000 nM
Compound 3: a limit, no number; the forecaster's own chance of this, stated with the estimate: 5%; middle value at least 16-fold (1.22 log units) from the limit.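

Going by these compounds alone, until now no measured pair showed what this position does. Putting hydrogen in place of methylsulfanyl, on an aromatic carbon para to a large group, gives an at least 22-fold higher number from compound 1 to compound 3 (1.35 log units; beyond the scatter), so in this assay the growth inhibition seen for compound 1 depends strongly on the group at this place. Compound 3 carries a limit of the assay, not a number: the limit of > 100000 nM in this assay, at which 1 of the 3 values shown sits.

As far as these compounds go, whether the sulfur atom is needed, or whether another group would serve equally well, stays open. A methoxy group, a chlorine atom or a longer chain such as ethylsulfanyl at this place could begin to answer that.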